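This account rests on a few compounds, and the source may have more. Where it says the series, first, only, none or still open, it means among the compounds named here.

Compound 1 `CC(=O)N1CCc2nc(C#Cc3ccccc3)sc2C1` gives in an assay on HEK293 cells for positive allosteric modulation of metabotropic glutamate receptor 5 (Homo sapiens), read by FLIPR, with a stated time of 1 h (a higher number here means that more compound is needed for the effect, a lower number that less compound is needed), a value that is a limit of the assay, > 10000 nM. Compound 2 `O=C(C1CCC1)N1CCc2nc(C#Cc3ccccc3)sc2C1` also gives only a limit here, > 10000 nM. Compound 3 `O=C(C1CCCO1)N1CCc2nc(C#Cc3ccccc3)sc2C1` gives 790 nM.

Within the data shown here, compound 3 thus stands as the only real number among the three; the others sit at a limit (the limit of > 10000 nM in this assay, at which 2 of the 3 values shown sit). The steps of an at least 12-fold lower number from compound 1 to compound 3 (1.10 log units; beyond the scatter) and an at least 12-fold lower number from compound 2 to compound 3 (1.10 log units; beyond the scatter) show that bringing in the oxolan-2-ylcarbonyl lowered the number strongly. Compound 4 `O=S(=O)(C1CC1)N1CCc2nc(C#Cc3ccccc3)sc2C1` removes that group: cyclopropylsulfonyl in place of (oxolan-2-yl)carbonyl on an amine nitrogen in a ring. The two measured steps bear on this only in reverse, so a large rise is expected in this assay. Compound 4 is therefore estimated at 8000 nM, between 2000 nM and 30000 nM, a step of a 10-fold higher number from compound 3 to compound 4 (1.01 log units; beyond the scatter) expected from compound 3.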

Compound 4, half-maximal effective concentration: > 10000 nM
Compound 4: a limit, no number (the forecaster's own chance of this, stated with the estimate: 60%); middle value at least 1.2-fold (0.09 log units) away from the limit.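

Replacing the (oxolan-2-yl)carbonyl with cyclopropylsulfonyl on this amine nitrogen gives an at least 12-fold higher number from compound 3 to compound 4 (1.10 log units; beyond the scatter) in this assay, so among the four compounds only the oxolan-2-yl amide, compound 3, gives a real number. Compound 4 gives > 10000 nM, which is a limit. The steps among compound 1, compound 2 and compound 4 cannot be read: the limit of > 10000 nM in this assay, at which 3 of the 4 values shown sit.

From the compounds shown here alone, whether a sulfonyl carrying an oxolan-2-yl group would give a real number stays open. So does whether an oxan-2-ylcarbonyl or pyrrolidin-2-ylcarbonyl group on this nitrogen would.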